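A few compounds are considered here, and "the series" means these few. Any claim that something is new, unique, unknown or untested is made for them only; others in the source may bear on it.

Measured so far in an ADME assay on Caco-2 cells (Homo sapiens) for permeability, read by LC-MS, in the apical to basolateral direction, with a stated time of 2 h; a higher number here means that the compound crosses the layer faster, a lower number that the compound crosses the layer more slowly:
compound 1 `COc1cc(C(=O)N2CCCC2)cc2nc(NCc3cccc(Cl)c3)oc12` gives "not determined" (no result reported);
compound 2 `COc1cc(C(=O)N2CCC(O)C(C)C2)cc2nc(NCc3cc(Cl)ccn3)oc12` gives 41 nm/s;
compound 3 `COc1cc(C(=O)N2CCC(O)C(C)C2)cc2nc(NCc3cncc(Cl)c3)oc12` gives 9.3 nm/s.

Compound 1 therefore has no number of its own, and it cannot be placed against compounds 2 and 3 on the numbers shown. The step from compound 1 to compound 4 `COc1cc(C(=O)N2CC(C)C(O)CC2CCO)cc2nc(NCc3cccc(Cl)c3)oc12` changes the group on the carbonyl carbon: 4-hydroxy-2-(2-hydroxyethyl)-5-methylpiperidin-1-yl in place of pyrrolidin-1-yl on a carbonyl carbon. Among the compounds with values here, the only measured step, a 4.4-fold lower number from compound 2 to compound 3 (0.64 log units; beyond the scatter), changes the aromatic ring on the other side of the shared core while the carbonyl side stays the same, so it bears on neither this position nor this kind of change. Within the data shown here, the only guide is that compound 2 and compound 3 carry a close relative of the entering group on their carbonyl carbon, and their numbers in this assay are modest. Because compound 2 gives 41 nm/s and compound 3 gives 9.3 nm/s with such a group in place, compound 4 is expected to fall near that region, estimated at 15 nm/s with a range from 3 nm/s to 60 nm/s.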

Compound 4, apparent permeability: 9.4 nm/s
The estimate for compound 4 lay 1.6-fold (0.20 log units) above the measured number, within the range that was stated.
By their numbers in this assay, from the lowest: compounds 3 and 4 (each within the scatter of the next); then compound 2.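

In this assay, within the data shown here, compound 1 gives "not determined" (no result reported) and so no step to compound 4 can be read, while compound 4 differs from compounds 2 and 3 in more than one place. Going by these compounds, what 4-hydroxy-2-(2-hydroxyethyl)-5-methylpiperidin-1-yl in place of pyrrolidin-1-yl does to the number stays open. Nothing shown explains the number of compound 4.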